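A few compounds are considered here, and "the series" means these few. Any claim that something is new, unique, unknown or untested is made for them only; others in the source may bear on it.

Measured in a physicochemical assay for solubility, measured as kinetic solubility; a lower number here means a less soluble compound, a higher number a more soluble compound:
- compound 1 `CNC(=O)c1cc(C(=O)N[C@H]2CC[C@H](O)CC2)c([C@@H](C)c2cccc(OC)c2)o1` gives the limit >= 113 ug/mL
- compound 2 `CCC(=O)c1c[nH]c(C(=O)NC)c1` gives 87 ug/mL
- compound 3 `CNC(=O)c1cc(C(=O)N[C@H]2[C@@H]3COC[C@@H]32)cc2c1O[C@H](CF)[C@H]2c1ccccc1` gives 206 ug/mL

Compound 1 has no exact number, only a limit (the limit of >= 113 ug/mL in this assay, at which 1 of the 3 values shown sits). Compounds 2 and 3 differ from it in more than one place, so no measured step sizes the change at hand.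

Compound 4 (`CNC(=O)c1cc(C(=O)N[C@H]2CC[C@H](O)CC2)c([C@@H](C)c2ccccc2Cl)o1`) carries 2-chlorophenyl in place of 3-methoxyphenyl on a saturated chain carbon bound to an aromatic carbon and a saturated chain carbon. The rest of the structure of compound 1 is kept.

A small downward step is expected in this assay (an at least 1.1-fold lower number from compound 1 to compound 4 (0.07 log units; that floor lies within the scatter)), not far beyond the scatter if beyond it at all. Among the measured compounds shown here, this expectation is loose, as the starting point is a limit and no measured pair tests this change. Compound 4 is estimated at 95 ug/mL with an expected range from 40 ug/mL to 190 ug/mL in this series.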

Compound 4, solubility: >= 242 ug/mL
Compound 4 gave a limit, no number (the forecaster's own chance of this, stated with the estimate: 35%); at least 2.5-fold (0.40 log units) between middle value and limit.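

Compound 1 and compound 4 both stand only as limits in this assay so no step can be read between them. The compounds shown leave open the size and direction of the change when 2-chlorophenyl takes the place of 3-methoxyphenyl.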